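Methyl Groups on the Pyrazole of a Dichloro EZH2 Inhibitor

The source may hold more compounds than are shown below. What is called first, only, known or untested is meant among the compounds shown, and "the series" means these compounds.

Compound 1 `COc1cccc(C(=O)NCc2c(C)cc(C)[nH]c2=O)c1F` is an open-chain analogue; in an assay on Sf9 cells for inhibition of histone-lysine N-methyltransferase EZH2 (Homo sapiens), read by scintillation counting, with a stated time of 60 min, in the presence of a further agent that is not named here (a lower number here means a stronger inhibitor, a higher number a weaker inhibitor), compound 1 gives only a limit of the assay, > 150000 nM. Compound 2 `Cc1cc(C)c(CN2CCc3c(F)cc(O[C@@H]4CCOC4)c(Cl)c3C2=O)c(=O)[nH]1` carries the shared core and gives 56 nM in this assay. Compound 3 `Cc1cc(C)c(CN2CCc3c(Cl)cc(-c4cn[nH]c4)c(Cl)c3C2=O)c(=O)[nH]1` carries chloro groups and a 1H-pyrazol-4-yl group on that core; in this assay compound 3 gives 51 nM, which sits beside the value of compound 2, within the usual scatter. Compound 4 `Cc1cc(C)c(CN2CCc3c(Cl)cc(-c4c(C)n[nH]c4C)c(Cl)c3C2=O)c(=O)[nH]1` differs from compound 3 by 3,5-dimethyl-1H-pyrazol-4-yl in place of 1H-pyrazol-4-yl on an aromatic carbon. For the measured compounds named here, no measured pair in this set shows such a change, so the estimate rests on compound 3 alone. The step of a 1.2-fold higher number from compound 3 to compound 4 (0.07 log units; within the scatter) is expected to stay within the scatter. Compound 4 is therefore expected to give about 60 nM, in a range from 15 nM to 250 nM.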

Compound 4, half-maximal inhibitory concentration in the histone-lysine N-methyltransferase EZH2 assay: 16 nM
Compound 4: middle estimate off by 3.8-fold (0.57 log units), on the high side; measured number inside the range.
By their numbers in the histone-lysine N-methyltransferase EZH2 assay, from the lowest: compound 4; then compounds 3 and 2 (each within the scatter of the next). At a limit, above all of these: compound 1.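

In the histone-lysine N-methyltransferase EZH2 assay, 3,5-dimethyl-1H-pyrazol-4-yl in place of 1H-pyrazol-4-yl gives a 3.2-fold lower number from compound 3 to compound 4 (0.50 log units; beyond the scatter). For the compounds shown here, this is the only measured pair at this aromatic carbon, and it shows that the number responds to substitution on the pyrazole. In a physicochemical assay for lipophilicity, at pH 7.4 (a higher number here means a more lipophilic compound, a lower number a more polar compound), compound 3 gives 3 and compound 4 gives 3.4. The same change also comes with higher measured lipophilicity: the measured distribution coefficient of compound 3, 3, and of compound 4, 3.4, a number 0.40 log units higher (beyond the scatter)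

This single pair cannot separate an effect of the methyl groups themselves from one that follows the lipophilicity. Going by these compounds, whether a single methyl group, or an ethyl group or an amine on the pyrazole, would give a similar step remains open.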